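The compounds below may be only part of what the source reports. "The series", "measured", "known", "first", "only" and "open" are said of these compounds alone.

Measured in a physicochemical assay for solubility, in phosphate buffer, at pH 7.4; on this read-out lower numbers stand for lower solubility and higher numbers for higher solubility:
- compound 1 `CCOC(=O)c1c(-c2ccccc2)[nH]c2cc(OC)ccc2c1=O`: > 100000 nM (a limit, not a number)
- compound 2 `CCOC(=O)c1c(-c2ccc(C(C)(C)C)cc2)[nH]c2cccc(OC)c2c1=O`: 1000 nM

Compound 1 sits at the limit of > 100000 nM in this assay, at which 1 of the 2 values shown sits. It therefore offers only a limit as a starting point, with no exact number.

Compound 3 `CCOC(=O)c1c(-c2cccc(OC)c2)[nH]c2cc(OC)ccc2c1=O` keeps the core of compound 1 and turns phenyl into 3-methoxyphenyl: methoxy in place of hydrogen on an aromatic carbon.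

Going by the values given here, no measured pair isolates this change. Compound 2 at 1000 nM shows that a number can be read in this series, but no single change links it to compound 1. A modest move towards lower numbers in this assay is expected, possibly none beyond the scatter, and compound 3 may well return a limit too. The expected size is an at least 1.6-fold lower number from compound 1 to compound 3 (0.22 log units; that floor lies within the scatter). The estimate for compound 3 is 60000 nM, with an expected range from 15000 nM to 100000 nM.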

Compound 3, solubility: > 100000 nM
Compound 3: only a limit was reported; the forecaster's own chance of this, stated with the estimate: 50%; at least 1.6-fold (0.22 log units) between middle value and limit.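

In this assay, going by these compounds alone, compound 1 and compound 3 both give only a limit, so no step between them can be read: the limit of > 100000 nM in this assay, at which 2 of the 3 values shown sit.

As far as these compounds go, whether methoxy in place of hydrogen on an aromatic carbon changes this read-out at all, and by how much, stays open.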